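Removing one methoxy in the shared core, second occurrence

This account rests on a few compounds, and the source may have more. Where it says the series, first, only, none or still open, it means among the compounds named here.

Compound 1 `O=C1C(Nc2ccc(-c3ccccc3)cc2)=CC(=O)c2ncncc21` carries a phenyl on the aniline side of the shared core, compound 2 `COc1ccc(-c2ccc(NC3=CC(=O)c4ncncc4C3=O)cc2)cc1` a 4-methoxyphenyl there, and compound 3 `COc1cc(NC2=CC(=O)c3ncncc3C2=O)cc(OC)c1OC` an aniline ring bearing methoxy groups directly. In a functional assay on BXPC-3 cells (Homo sapiens) for cytotoxicity, read by MTT assay, with a stated time of 72 h (on this read-out higher numbers stand for weaker inhibition and lower numbers for stronger inhibition), compound 1 gives 500 nM, compound 2 gives 3500 nM and compound 3 gives 1600 nM. The change hydrogen in place of methoxy on an aromatic carbon produced a 7.0-fold lower number from compound 2 to compound 1 (0.85 log units; beyond the scatter). How the cores of compound 3 and compound 2 differ is not broken down here; their two numbers only show compound 3 sitting between compound 2 and compound 1.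

Compound 4 `COc1ccc(NC2=CC(=O)c3ncncc3C2=O)cc1OC` is not yet measured in this assay. It is reached from compound 3 by hydrogen in place of methoxy on an aromatic carbon. Going by the values given here, this is the same kind of change as the one made from compound 2 to compound 1, not the same change: in compound 2 the leaving methoxy is para to a large group, whereas in compound 3 it is ortho to a methoxy group, meta to a large group and meta to a methoxy group.

Because a 7.0-fold lower number from compound 2 to compound 1 (0.85 log units; beyond the scatter) the same kind of change is expected to lower the number for compound 4 as well, though the different surroundings and a single precedent argue for a smaller step. For compound 4 the expected step is a 2.3-fold lower number from compound 3 to compound 4 (0.36 log units; beyond the scatter). Compound 4 is expected at 700 nM in this assay, with a range from 250 nM to 2500 nM.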

Compound 4, half-maximal inhibitory concentration: 1500 nM
Estimate against measurement, compound 4: 2.1-fold (0.33 log units) below; low and high end bracket the measured number.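

In this assay, hydrogen in place of methoxy on an aromatic carbon gives a 1.1-fold lower number from compound 3 to compound 4 (0.03 log units; within the scatter), so this step cannot separate compound 3 from compound 4, and it does not repeat the clear step seen on the other core: the same change on two cores in this assay, a 7.0-fold lower number (0.85 log units; beyond the scatter) from compound 2 to compound 1 and a 1.1-fold lower number (0.03 log units; within the scatter) from compound 3 to compound 4, 6.6-fold (0.82 log units) apart, beyond the scatter of two such steps

For this series, the size of the step read from compound 2 to compound 1 does not carry over to the core of compound 3, and a transfer from one core to another is not supported by these compounds. Going by these compounds alone, the result rests on only two matched pairs and does not show which difference matters: the surroundings of the leaving methoxy, which here is ortho to a methoxy group and meta to both a large group and another methoxy group, or some other feature of the two aniline sides.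

Still open, on these data alone, is whether the step stays this small when the remaining methoxy groups of compound 4 are removed one at a time, leaving a singly substituted or unsubstituted aniline ring. Also open, as far as these compounds go, is how a hydroxy group, a fluorine atom or an amine would compare with methoxy at the same place on either core.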